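This account rests on a few compounds, and the source may have more. Where it says the series, first, only, none or still open, it means among the compounds named here.

Measured so far:
compound 1, `CN(C)CCCn1c(=O)n(C2OC(CO)[C@@H](O)[C@H]2O)c2nc(N)nc(O)c21`, 63%
compound 2, `C=CCn1c(=O)n(CCCC)c2nc(N)nc(O)c21`, 36%

In a functional assay on the whole organism with Mus musculus as the target (on this read-out higher numbers stand for larger maximal responses and lower numbers for smaller maximal responses), compound 1 gives 63%, the higher of the two numbers; compound 2 gives 36%, a gap beyond the usual scatter. Compound 3, `CCn1c(=O)n(C2OC(CO)[C@@H](O)[C@H]2O)c2nc(N)nc(O)c21`, differs from compound 1 in one place: hydrogen in place of (dimethylamino)methyl on a saturated chain carbon, two bonds along the chain from an aromatic nitrogen. Going by the values given here, no measured pair shows this change, so its size is unknown. Putting hydrogen in place of (dimethylamino)methyl is expected to lower the maximal response only modestly, a step of a number 13 percentage points lower from compound 1 to compound 3 (beyond the scatter) that may well sit within the scatter. Compound 3 is therefore estimated at 50%, within a range from 25% to 75%.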

Compound 3, largest response reached (reported as maximal response), in percent of the reference or control that the assay uses: 82%
Compound 3: middle estimate off by 32 percentage points, on the low side; measured number above the stated range.
By their numbers in this assay, from the lowest: compound 2; then compound 1; then compound 3.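

Going from 3-(dimethylamino)propyl to ethyl on this aromatic nitrogen removes the amine end of the chain, yet in this assay the result is a number 19 percentage points higher from compound 1 to compound 3 (beyond the scatter), so at this position the dimethylamino group is not required for a large maximal response. The shorter chain gives the larger response of this pair. Nothing available here explains the rise.

On these data alone, this single change shortens the chain and removes the amine together, so their separate contributions remain open. A plain propyl chain at this position would separate the two, and a methyl group would show whether shortening further still raises the response.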